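The source may hold more compounds than are shown below. What is called first, only, known or untested is meant among the compounds shown, and "the series" means these compounds.

In an ADME assay on Vero cells (Chlorocebus sabaeus) for cytotoxicity, read by MTT assay (a lower number here means a stronger inhibitor, a higher number a weaker inhibitor), compound 1, `CN(Cc1ccccc1)c1cc(C(=O)Nc2ccccc2)ncn1`, gives 314000 nM, and its fluoro analogue, compound 2, `CN(Cc1ccc(F)cc1)c1cc(C(=O)Nc2ccccc2)ncn1`, gives 297000 nM. Among the measured compounds shown here, compound 2 therefore stands level with compound 1, the only other compound measured, and the two numbers lie within the scatter of each other. The next compound, compound 3, `COCCOc1ccc(NC(=O)c2cc(N(C)Cc3ccc(F)cc3)ncn2)cc1`, keeps the framework of compound 2 but adds 2-methoxyethoxy in place of hydrogen on an aromatic carbon. For the measured compounds named here, only one measured step bears on this change, a 1.1-fold lower number from compound 1 to compound 2 (0.02 log units; within the scatter), and it concerns fluoro rather than 2-methoxyethoxy, at a different place, so it offers only weak guidance. With so little to go on, only a small shift in this assay is expected, leaning towards a lower number, with an estimated 1.5-fold lower number from compound 2 to compound 3 (0.17 log units; within the scatter). For compound 3 the expected value is 200000 nM, with an estimated range from 80000 nM to 450000 nM.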

Compound 3, half-maximal inhibitory concentration: 244000 nM
For compound 3 the middle estimate is 1.2-fold (0.09 log units) below the measured one; the range from low to high includes it.
By their numbers in this assay, from the lowest: compounds 3, 2 and 1 (each within the scatter of the next).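

In this assay, placing 2-methoxyethoxy on an aromatic carbon of the six-membered ring of carbon only, para to a large group, gives a 1.2-fold lower number from compound 2 to compound 3 (0.09 log units; within the scatter). This position therefore accepts a chain of this size without carrying the number beyond the scatter, which the earlier fluoro step, at a different place, could not show. No measurement at hand explains this result.

From the compounds shown here alone, whether an amine, a carboxylic acid or a longer chain at this same place would also stay within the scatter of compound 2 in this assay remains open. Also open, going by these compounds, is whether any change at this position can move the number beyond the scatter at all.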